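Notes on a small adenosine receptor A3 series

The source may report more compounds than this note shows. Statements on the series, on what has been measured and on what is new or still open speak of the compounds shown alone.

Measured compounds:
compound 1 `CCCn1c(=O)[nH]c2nc(-c3ccc(S(=O)(=O)N4CCN(Cc5cccc(C)c5)CC4)cc3)[nH]c2c1=O` 17%
compound 2 `CCCn1c(=O)[nH]c2nc(-c3ccc(S(=O)(=O)N4CCN(C)CC4)cc3)[nH]c2c1=O` 7%
compound 3 `CCCn1c(=O)[nH]c2nc(-c3ccc(S(=O)(=O)N4CCN(C(C)c5ccccc5)CC4)cc3)[nH]c2c1=O` 0%

All three share a core and differ only in the group on the amine nitrogen in a ring. In an assay on CHO cells for displacement of a labelled ligand from adenosine receptor A3 (Homo sapiens), read by scintillation counting, with a stated time of 45 min, tested at 1 uM, in the presence of a further agent that is not named here (a lower number here means less inhibition, a higher number more inhibition at the concentration tested (going by the name of the read-out)), compound 2 gives 7%, the second highest of the three numbers; its nearest neighbour is compound 3 with a number 7 percentage points lower from compound 2 to compound 3 (within the scatter), and its furthest is compound 1, where a number 10 percentage points lower from compound 1 to compound 2 (within the scatter).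

Compound 4 `CCCn1c(=O)[nH]c2nc(-c3ccc(S(=O)(=O)N4CCN(Cc5ccc(Br)c(F)c5)CC4)cc3)[nH]c2c1=O` is the next member. Relative to compound 2 the change is 4-bromo-3-fluorophenyl in place of hydrogen on a saturated chain carbon bound to an amine nitrogen in a ring.

Within the data shown here, the step that bears most directly on this is the one from compound 1 to compound 2, where a hydrogen replaced a 3-methylphenyl at the same place: a number 10 percentage points lower from compound 1 to compound 2 (within the scatter). The other step away from compound 2, to compound 3, was a number 7 percentage points lower from compound 2 to compound 3 (within the scatter). Both stayed within the scatter, so no step beyond the scatter is expected in this assay in either direction, with at most a slight rise. Compound 4 is therefore estimated at 15%, within 2% to 32%, which means an expected a number 8 percentage points higher from compound 2 to compound 4 (within the scatter).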

Compound 4, a percentage reported as inhibition, at one concentration (the size of the read-out at that concentration, not a potency): 27%
Compound 4: the middle estimate sits 12 percentage points below what was measured, and the stated range covers the measured number.
By their numbers in this assay, from the lowest: compounds 3, 2, 1 and 4 (each within the scatter of the next, the first and the last beyond it).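

In this assay the 4-bromo-3-fluorobenzyl group on the amine nitrogen in a ring gives a number 20 percentage points higher from compound 2 to compound 4 (beyond the scatter), so a substituted benzyl at this place now stands clear of methyl, which the 3-methylbenzyl of compound 1 did not show. The same group also separates from 1-phenylethyl, with a number 27 percentage points higher from compound 3 to compound 4 (beyond the scatter), while exchanging the aryl group on the saturated chain carbon leaves a number 10 percentage points higher from compound 1 to compound 4 (within the scatter), so compound 1 and compound 4 cannot be ordered. No available evidence accounts for these steps.

Whether the bromine or the fluorine carries the step remains open, since 4-bromophenyl and 3-fluorophenyl do not appear among the compounds shown. Also open, from the compounds shown here alone, is how a carboxylic acid on the phenyl ring, or a longer chain in place of the benzyl carbon, would read in this assay.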